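Replacing 3-Nitrophenyl With 1,3-Benzothiazol-2-yl: Expected Cytotoxicity

A few compounds are considered here, and "the series" means these few. Any claim that something is new, unique, unknown or untested is made for them only; others in the source may bear on it.

Measured compounds:
- Compound 1 `COc1ccc(/C=C\C(=O)O)c(OCc2cn(-c3ccccc3C(=O)N3CCC(O)C3)nn2)c1CC=C(C)C` — in a functional assay on A549 cells (Homo sapiens) for cytotoxicity, read by MTT assay, with a stated time of 24 h (on this read-out lower numbers stand for stronger inhibition and higher numbers for weaker inhibition), compound 1 gives "not determined" (no result reported)
- Compound 2 `COc1ccc(/C=C\C(=O)O)c(OCc2cn(-c3cccc([N+](=O)[O-])c3)nn2)c1CC=C(C)C` — in this assay compound 2 gives "not determined" (no result reported)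
- Compound 3 `COc1ccc(/C=C\C(=O)O)c(OCc2cn(-c3ccc(NC(=O)c4ccccc4)cc3)nn2)c1CC=C(C)C` — in this assay compound 3 gives 42700 nM

All three share one core, and differ only in the group carried on the aromatic nitrogen of the five-membered ring. Compound 4 `COc1ccc(/C=C\C(=O)O)c(OCc2cn(-c3nc4ccccc4s3)nn2)c1CC=C(C)C` carries yet another such group and has not been measured.

In this assay compound 2 stands without a single number; compound 1 is a further entry without one. Only compound 3 gives a number there, and that number, 42700 nM for compound 3, points to weak inhibition.

The change from compound 2 to compound 4 is 1,3-benzothiazol-2-yl in place of 3-nitrophenyl on an aromatic nitrogen.

Going by the values given here, no step between two measured compounds is known here, so nothing shows how much the read-out in this assay moves when the group on the ring nitrogen is exchanged. With no anchor for compound 2 and only the weak result of compound 3 as a guide, no direction can be stated for this step; the expectation is simply that compound 4 stays in the weak range, with a wide spread. Compound 4 is expected to give about 40000 nM in this assay, within a range from 10000 nM to 150000 nM.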

Compound 4, half-maximal inhibitory concentration: 42100 nM
Estimate against measurement, compound 4: 1.1-fold (0.02 log units) below, within the range that was stated.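

In this assay compound 4 gives 42100 nM, while compound 2 has no single number there, and the step between compound 2 and compound 4 cannot be read. The compounds shown leave open how far exchanging the group on the ring nitrogen moves this read-out. No evidence here bears on the value of compound 4.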